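Three inactive sulfonamides and a descyclopropyl analogue

This account rests on a few compounds, and the source may have more. Where it says the series, first, only, none or still open, it means among the compounds named here.

Measured compounds, with the half-maximal inhibitory concentration in a functional assay on DLD-1 cells (Homo sapiens) for antiproliferative activity, read by CellTiter-Glo, with a stated time of 72 h; on this read-out lower numbers stand for stronger inhibition and higher numbers for weaker inhibition:
- compound 1 `CCc1ccc(S(=O)(=O)N2CCC(N3CCC(C)CC3)CC2)cc1`: > 5000 nM, a limit of the assay
- compound 2 `CC1CCN(C2CCN(S(=O)(=O)c3cccnc3Cl)CC2)CC1`: > 5000 nM, a limit of the assay
- compound 3 `CC1CCN(C2CCN(S(=O)(=O)c3sc(Cl)nc3C3CC3)CC2)CC1`: > 5000 nM, a limit of the assay

Compound 3 therefore stands at a limit and nowhere else on the numbers shown; in this assay every shown value is such a limit (the limit of > 5000 nM in this assay, at which 3 of the 3 values shown sit). Among the compounds with values here, the only step between measured compounds, a step that the two limits leave unreadable from compound 1 to compound 2, is unreadable, since both of its ends are limits.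

Compound 4 `CC1CCN(C2CCN(S(=O)(=O)c3cnc(Cl)s3)CC2)CC1` differs from compound 3 by hydrogen in place of cyclopropyl on an aromatic carbon.

Within the data shown here, no measured step bears on this change, and no measured number anywhere gives a foothold beyond the limit. The expectation for compound 4 is therefore that the assay again returns a limit, with no readable step; the expected step that the limit leaves unreadable from compound 3 to compound 4 is no more than the scatter. Compound 4 is estimated at 10000 nM in this assay, with a range from 4000 nM to 30000 nM.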

Compound 4, half-maximal inhibitory concentration: 1800 nM
Compound 4: the middle estimate sits 5.6-fold (0.74 log units) above what was measured; measured number outside the range, below it.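

In this assay, within the data shown here, hydrogen in place of cyclopropyl on the aromatic carbon next to the ring nitrogen gives an at least 2.7-fold lower number from compound 3 to compound 4 (0.44 log units; beyond the scatter), so the first readable number appears only once the cyclopropyl has left this position. The 2-chloro-1,3-thiazol-5-yl group on the sulfonyl sulfur also stands apart from the other two groups there, with an at least 2.7-fold lower number from compound 2 to compound 4 (0.44 log units; beyond the scatter) and an at least 2.7-fold lower number from compound 1 to compound 4 (0.44 log units; beyond the scatter), while the step between those two groups cannot be read. Each of these three sizes is only a bound, since one end of each step is a limit: the limit of > 5000 nM in this assay, at which 3 of the 4 values shown sit.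

Going by these compounds, whether a methyl group or an amine at this aromatic carbon would keep the number of compound 4 remains open, as does the true size of each step. On these data alone, the part played by the chloro group of compound 4 also stays open, with a nitrile there as one possible comparison.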